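Indanyl in place of benzyl on the piperidinylmethyl amine

The source may report more compounds than this note shows. Statements on the series, on what has been measured and on what is new or still open speak of the compounds shown alone.

Measured so far:
compound 1 `c1ccc(C2CCCCN2C2CCN(CCCc3c[nH]c4ccc(-n5cnnc5)cc34)CC2)cc1` gives 410 nM
compound 2 `c1ccc(CNCC2CCN(CCCc3c[nH]c4ccc(-n5cnnc5)cc34)CC2)cc1` gives 28 nM
compound 3 `CNS(=O)(=O)Cc1ccc2[nH]cc(CCCN3CCC(N[C@H](C)c4ccccc4)CC3)c2c1` gives 260 nM

In an assay on CHO cells for displacement of a labelled ligand from 5-hydroxytryptamine receptor 1B (Homo sapiens) (a lower number here means a stronger inhibitor, a higher number a weaker inhibitor), compound 2 returns the lowest of the three numbers. The nearest of the others is compound 3 at 260 nM, and the furthest is compound 1 at 410 nM; both gaps lie beyond the scatter, so compound 2 is the strongest inhibitor of the three. Compound 3 carries a different core as well as a different amine substituent, and compound 1 a different arrangement at the piperidine, so neither gap can be read as a single change; the values are simply what they are.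

Compound 4 `c1ccc2c(c1)CCC2NCC1CCN(CCCc2c[nH]c3ccc(-n4cnnc4)cc23)CC1` has not yet been measured. It keeps the core of compound 2 and differs in one place:
2,3-dihydro-1H-inden-1-yl in place of benzyl on an amine nitrogen

For the measured compounds named here, no step between measured compounds bears on this change. The expectation is therefore a small shift, most likely toward a higher number, and not beyond the scatter. For compound 4 in this assay the estimate is 50 nM, with a range from 12 nM to 200 nM. The expected step of a 1.8-fold higher number from compound 2 to compound 4 (0.25 log units; within the scatter) is taken to lie within the usual scatter.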

Compound 4, half-maximal inhibitory concentration: 25 nM
Beside the measured number, compound 4's estimate is 2.0-fold (0.30 log units) above it; the range from low to high includes it.
By their numbers in this assay, from the lowest: compounds 4 and 2 (each within the scatter of the next); then compounds 3 and 1 (each within the scatter of the next).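

In this assay, for the compounds shown here, the exchange of benzyl for 2,3-dihydro-1H-inden-1-yl on the amine nitrogen gives a 1.1-fold lower number from compound 2 to compound 4 (0.05 log units; within the scatter) and provides the first comparison that differs in one place only. This position, on an amine nitrogen whose other neighbour is a saturated chain carbon, therefore accepts the added five-membered non-aromatic ring of carbon, with 9 heavy atoms in place of 7, without a step that can be told from the scatter; this single pair shows that for this one group and no further. Nothing measured on these compounds gives a reason for this result.

On these data alone, whether the same holds for a group with no aromatic ring, such as cyclohexyl, or for a longer chain from the amine nitrogen to the phenyl ring, such as 2-phenylethyl, remains open. Also open, as far as these compounds go, is the outcome when a methyl or an acetyl replaces the hydrogen on that amine nitrogen, with benzyl or 2,3-dihydro-1H-inden-1-yl kept in place on the shared core.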